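Ethyl Gives Way to Cyclopropyl

The source may report more compounds than this note shows. Statements on the series, on what has been measured and on what is new or still open speak of the compounds shown alone.

Of the compounds shown here, two have so far been measured in a physicochemical assay for solubility, in phosphate buffer, at pH 7.2; a lower number here means a less soluble compound, a higher number a more soluble compound. Compound 1 (`COc1cc(C2CN(C(=O)c3cc(COC[C@H](O)CO)ccn3)C2)ccc1OCc1ccc(C2CC2)cc1`) gives 6700 nM. Compound 2 (`CCc1ccc(COc2ccc(C3CN(C(=O)c4cc(COCC(CO)(CO)CO)ccn4)C3)cc2OC)cc1`) gives 2800 nM, the lower of the two numbers, and the gap between them lies beyond the usual scatter of repeated measurements. Within the data shown here, no two measured compounds differ in just one place, so no measured step shows what a single change does here.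

Compound 3 (`COc1cc(C2CN(C(=O)c3cc(COCC(CO)(CO)CO)ccn3)C2)ccc1OCc1ccc(C2CC2)cc1`) has not yet been measured. It departs from compound 2 at one spot: cyclopropyl in place of ethyl on an aromatic carbon. In words, cyclopropyl stands in place of ethyl on an aromatic carbon, para to a large group. Among the measured compounds shown here, with no measured example of this swap, the expectation starts from compound 2 at 2800 nM and assumes little movement. In this assay, the expected step is slightly downward and stays within the scatter, a 1.1-fold lower number from compound 2 to compound 3 (0.03 log units; within the scatter). For compound 3, the estimated solubility is 2600 nM, with a likely range from 1200 nM to 5500 nM.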

Compound 3, solubility: 1500 nM
Estimate against measurement, compound 3: 1.7-fold (0.24 log units) above; the range from low to high includes it.
By their numbers in this assay, from the lowest: compounds 3 and 2 (each within the scatter of the next); then compound 1.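

In this assay there are now two comparisons between compounds that differ in one place. On an aromatic carbon para to a large group, cyclopropyl in place of ethyl gives a 1.9-fold lower number from compound 2 to compound 3 (0.27 log units; within the scatter) and so, despite the added ring and the extra carbon, this first measured change at the position cannot be told apart from the differences seen between repeated measurements. The second comparison keeps cyclopropyl fixed and puts 2-hydroxy-1,1-bis(hydroxymethyl)ethyl in place of 1,2-dihydroxyethyl on a saturated chain carbon bound to an oxygen on a saturated carbon, giving a 4.5-fold lower number from compound 1 to compound 3 (0.65 log units; beyond the scatter) and thus a modest step that is larger than that scatter. Of the two places where compound 1 and compound 2 differ, only the chain change, taken alone, shows a step beyond the scatter, and no supporting data explain why.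

Still open, going by these compounds, is how a longer chain such as propyl, an amine or a carboxylic acid would read on that aromatic carbon. Also open is whether the chain step would be the same size with ethyl in place of cyclopropyl, since the compounds shown test it only with cyclopropyl present.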